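The compounds below may be only part of what the source reports. "The series", "measured", "known", "first", "only" and "open" are said of these compounds alone.

Compound 1 `N#Cc1c(Cl)nc(SCc2nc3ccccc3[nH]2)nc1-c1ccccc1` gives 8.62 nM in a functional assay on GOTO cells (Homo sapiens) for cytotoxicity, read by MTT assay, with a stated time of 3 days; on this read-out lower numbers stand for stronger inhibition and higher numbers for weaker inhibition.
Compound 2 `N#Cc1c(Nc2nccs2)nc(SCc2nc3ccccc3[nH]2)nc1-c1ccccc1` gives 5.1 nM in this assay.

Within the data shown here, of the two numbers, compound 1 stands at the higher one, and its only neighbour is compound 2, separated by a 1.7-fold lower number from compound 1 to compound 2 (0.23 log units; within the scatter). Compound 3 `N#Cc1c(-c2ccccc2)nc(SCc2nc3ccccc3[nH]2)nc1N1CCNCC1` differs from compound 1 by piperazin-1-yl in place of chloro on an aromatic carbon. Among the measured compounds shown here, the single step that bears on this site, the exchange of chloro in compound 1 for an amino substituent in compound 2, stayed within the scatter. No step beyond the scatter is therefore expected, and the expected change is a 1.1-fold lower number from compound 1 to compound 3 (0.03 log units; within the scatter). Compound 3 is estimated at 8 nM, expected to fall between 2.5 nM and 30 nM.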

Compound 3, half-maximal inhibitory concentration: 3.7 nM
Compound 3: the middle estimate sits 2.2-fold (0.33 log units) above what was measured; measured number inside the range.
By their numbers in this assay, from the lowest: compounds 3, 2 and 1 (each within the scatter of the next, the first and the last beyond it).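

Among these compounds, the exchange of chloro for piperazin-1-yl on this aromatic carbon gives a 2.3-fold lower number from compound 1 to compound 3 (0.37 log units; beyond the scatter) and is the first step at this position beyond the scatter, though a modest one. Piperazin-1-yl and (1,3-thiazol-2-yl)amino cannot be told apart, with a 1.4-fold lower number from compound 2 to compound 3 (0.14 log units; within the scatter) as the step between them. No evidence is available to explain the step from chloro.

From the compounds shown here alone, whether this step depends on the second ring nitrogen of piperazin-1-yl remains open. Morpholine or an open-chain amine such as dimethylamino on this carbon would address that.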